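A few compounds are considered here, and "the series" means these few. Any claim that something is new, unique, unknown or untested is made for them only; others in the source may bear on it.

Among the compounds with values here, in a functional assay on U2OS cells (Homo sapiens) for antiproliferative activity, read by MTT assay, with a stated time of 72 h (a higher number here means a weaker inhibitor, a lower number a stronger inhibitor), compound 1 (`Cc1ccc(SCC(=O)Nc2ccc3nc(NC(=O)c4ccc(C(F)(F)F)cc4)sc3c2)c(C)c1`) gives 1000 nM and stands lowest of the three numbers so far, which makes it the strongest inhibitor measured. Compound 3 (`Cc1ccc(C(=O)Nc2nc3ccc(NC(=O)CSc4ccc(Cl)cc4)cc3s2)cc1`) gives 3190 nM and compound 2 (`CCCC(=O)Nc1nc2ccc(NC(=O)CSc3cccc(O)c3)cc2s1`) gives 10100 nM there, and both lie beyond the usual scatter from compound 1. Compound 4 (`O=C(CSC1CCCCC1)Nc1ccc2nc(NC(=O)c3ccc(C(F)(F)F)cc3)sc2c1`) has not yet been measured. Within the data shown here, it keeps the rest of compound 1 but carries cyclohexyl in place of 2,4-dimethylphenyl on a sulfur as its only change. Among the measured compounds shown here, all three measured compounds carry an aromatic ring on that sulfur, so no measured pair shows what a non-aromatic ring does there. With compound 1 already at 1000 nM at the low end of the numbers, a modest weakening is expected rather than a gain. The estimated step of a 2.0-fold higher number from compound 1 to compound 4 (0.30 log units; within the scatter) would sit near the edge of the usual scatter. In this assay the estimate for compound 4 is 2000 nM with a range of 700 nM to 6000 nM (expected, not measured).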

Compound 4, half-maximal inhibitory concentration: 12300 nM
Beside the measured number, compound 4's estimate is 6.2-fold (0.79 log units) below it; the measured number lies above the stated range.
By their numbers in this assay, from the lowest: compound 1; then compound 3; then compounds 2 and 4 (each within the scatter of the next).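

In this assay, within the data shown here, cyclohexyl in place of 2,4-dimethylphenyl on a sulfur brings a 12-fold higher number from compound 1 to compound 4 (1.09 log units; beyond the scatter) and this is the first comparison at this position in which only one group changes. It shows that the group on this sulfur cannot be exchanged freely: with the rest of compound 1 kept, a six-membered aromatic ring of carbon gives a much lower number than a six-membered non-aromatic ring of carbon. Nothing measured here says what lies behind this step.

On these data alone, it remains open whether the aromatic ring alone or also its two methyl groups matter, and plain phenyl on the same sulfur, with the rest of compound 1 kept, would separate the two. How a small open chain such as ethyl or a ring carrying an amine would fare there is also unknown.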